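Changing one group on a sulfonamide series

A few compounds are considered here, and "the series" means these few. Any claim that something is new, unique, unknown or untested is made for them only; others in the source may bear on it.

Measured in a physicochemical assay for acid dissociation:
- Compound 1 `CC(=O)NCc1cccc(Cn2nc(NS(=O)(=O)c3ccc(Cl)s3)c3c(Cl)cccc32)c1`: 6.03
- Compound 2 `CC(=O)NCc1cccc(Cn2nc(NS(=O)(=O)c3ccc(Cl)s3)c3c(F)cccc32)c1`: 5.62
- Compound 3 `CC(=O)NCc1cccc(Cn2nc(NS(=O)(=O)c3ccc(Cl)s3)c3c(C#N)cccc32)c1`: 5.4

Compound 3 sits at the low end of these values, though not clearly apart from its nearest neighbour: a number 0.22 log units lower from compound 2 to compound 3 (within the scatter). The gap to the highest value is larger: a number 0.63 log units lower from compound 1 to compound 3 (beyond the scatter). Compound 4 `CC(=O)NCc1cccc(Cn2nc(NS(=O)(=O)c3ccc(Cl)s3)c3c(C(C)(C)O)cccc32)c1` carries 1-hydroxy-1-methylethyl in place of cyano on an aromatic carbon. For the measured compounds named here, no measured compound carries this group, so only the swaps at this carbon offer guidance, such as a number 0.41 log units lower from compound 1 to compound 2 (beyond the scatter). With compound 3 at the low end and compound 1 at 6.03, a modest rise seems likeliest. The expected change is a number 0.70 log units higher from compound 3 to compound 4 (beyond the scatter). For compound 4 the estimate is 6.1, with an expected range from 5.6 to 6.7.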

Compound 4, acid dissociation constant: 5.46
Compound 4: middle estimate off by 0.64 log units, on the high side; measured number below the stated range.
By their numbers in this assay, from the lowest: compounds 3, 4 and 2 (each within the scatter of the next); then compound 1.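

In this assay, 1-hydroxy-1-methylethyl at this aromatic carbon, which brings a hydrogen-bond donor, is not distinguishable from cyano (a number 0.06 log units higher from compound 3 to compound 4 (within the scatter)) or from fluoro (a number 0.16 log units lower from compound 2 to compound 4 (within the scatter)). Only chloro stands apart from it (a number 0.57 log units lower from compound 1 to compound 4 (beyond the scatter)), so these very different groups form one cluster, with compound 1 alone outside it. No supporting measurement accounts for this grouping. As far as these compounds go, whether an amine or a carboxylic acid at this carbon would join the cluster or sit nearer compound 1 remains open. So does whether a plain methyl would match compound 4.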